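From Methyl to Heptyl on Compound 2

This account rests on a few compounds, and the source may have more. Where it says the series, first, only, none or still open, it means among the compounds named here.

Values so far in a functional assay on HL-60 cells (Homo sapiens) for cytotoxicity; on this read-out lower numbers stand for stronger inhibition and higher numbers for weaker inhibition
Compound 1 `CC(=O)OCC1=C[C@H](OCc2ccc3ccccc3c2)[C@H](O)[C@@H](O)C1=O` gives > 50000 nM (a limit)
Compound 2 `CO[C@H]1C=C(COC(C)=O)C(=O)[C@H](O)[C@H]1O` gives > 50000 nM (a limit)
Compound 3 `CCCCCO[C@@H]1C=C(COC(C)=O)C(=O)[C@H](O)[C@H]1O` gives 2600 nM

Compound 2 gives > 50000 nM, which is a limit of the assay and not a number. This is the limit of > 50000 nM in this assay, at which 2 of the 3 values shown sit. For the measured compounds named here, compound 3 gives 2600 nM, the only true number measured so far.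

Compound 4 `CCCCCCCO[C@H]1C=C(COC(C)=O)C(=O)[C@H](O)[C@H]1O` is compound 2 with a single change: hexyl in place of hydrogen on a saturated chain carbon bound to an oxygen on a saturated carbon. Put another way, the methyl of compound 2 becomes a heptyl. Going by the values given here, no measured pair of compounds shows directly what such a change does in this assay, so any forecast here is uncertain. Even so, a large step toward stronger inhibition is expected, well beyond the usual scatter. The main support is compound 3, which gives 2600 nM, a number rather than a limit. The step expected on this reasoning is an at least 16-fold lower number from compound 2 to compound 4 (1.22 log units; beyond the scatter). A result at the limit again remains possible. For compound 4 the estimated value is 3000 nM, with an expected range of 800 nM to 15000 nM.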

Compound 4, half-maximal inhibitory concentration: 39800 nM
The estimate for compound 4 lay 13-fold (1.12 log units) below the measured number; measured number above the stated range.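

In this assay compound 2, with its methyl, gives > 50000 nM, which is a limit and not a number. Compound 4, with its heptyl, gives a true number of 39800 nM, which shows that a heptyl at this place does yield a reading, though not one far from the top of the range tested. The change can only be stated as an at least 1.2-fold lower number from compound 2 to compound 4 (0.09 log units; that floor lies within the scatter), and that floor lies within the usual scatter, so no real gain is proven because the starting value is not a number: the limit of > 50000 nM in this assay, at which 2 of the 4 values shown sit.

Compound 3, with a pentyl, gives 2600 nM, but the carbon carrying its chain is drawn with the opposite handedness to that in compound 4, so the two differ in more than one place and the effects of chain length and handedness cannot be separated. On these data alone, it remains open how a pentyl with the handedness of compound 4 would read, and whether a longer chain such as nonyl or an amine at the chain end would change the result.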